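The source may hold more compounds than are shown below. What is called first, only, known or untested is meant among the compounds shown, and "the series" means these compounds.

Going by the values given here, in a functional assay on HeLa cells (Homo sapiens) for inhibition, read by sulforhodamine B assay (a higher number here means a weaker inhibitor, a lower number a stronger inhibitor), compound 2 `O=C1C=C(Nc2ccccc2)C(=O)c2c1nc1n2[C@H]2OC[C@@H](O)[C@H]2OC1` gives 5620 nM, the only plain number among the three measured compounds. Compound 1 `O=C1C(NC2CC2)=CC(=O)c2c1nc1n2[C@H]2OC[C@@H](O)[C@H]2OC1` reaches only the limit of > 16000 nM. Compound 3 `O=C1C=C(N2CCCCC2)C(=O)c2c1nc1n2[C@H]2OC[C@@H](O)[C@H]2OC1` likewise stops at the limit of > 16000 nM. Among the compounds with values here, the single measured step, an at least 2.8-fold higher number from compound 2 to compound 3 (0.45 log units; beyond the scatter), ends at the limit of > 16000 nM in this assay, at which 2 of the 3 values shown sit. Compound 4 `CCOc1ccc(NC2=CC(=O)c3nc4n(c3C2=O)[C@H]2OC[C@@H](O)[C@H]2OC4)cc1` differs from compound 2 by ethoxy in place of hydrogen on an aromatic carbon. Within the data shown here, no measured step alters the anilino group in this way; the step from compound 2 to compound 3 swaps the whole group and so gives little guidance here. The expectation is therefore a step within the scatter, a 1.1-fold lower number from compound 2 to compound 4 (0.05 log units; within the scatter). Compound 4 is estimated at 5000 nM in this assay, with a range from 1500 nM to 16000 nM.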

Compound 4, half-maximal inhibitory concentration: 3110 nM
Estimate against measurement, compound 4: 1.6-fold (0.21 log units) above; the measured number falls inside the stated range.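

In this assay, ethoxy on the aromatic ring of the anilino group gives a 1.8-fold lower number from compound 2 to compound 4 (0.26 log units; within the scatter), so this ring can carry the added chain with no difference that can be told from the scatter. Where earlier the whole group was swapped, this smaller change shows what happens on the ring itself. Compound 4, like compound 2, gives a plain number rather than a limit, which keeps this ring open to comparison: the limit of > 16000 nM in this assay, at which 2 of the 4 values shown sit.

As far as these compounds go, whether an amine or a carboxylic acid at this place would shift the number beyond the scatter stays open. So does the effect of ethoxy on another carbon of the ring.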